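From Ethyl to Ethoxy on Compound 2

This account rests on a few compounds, and the source may have more. Where it says the series, first, only, none or still open, it means among the compounds named here.

Of the compounds shown here, three with a shared core have been measured in an in vitro ADME assay on microsomes from liver (Simiiformes); on this read-out higher numbers stand for a longer-lived compound and lower numbers for a shorter-lived compound. Compound 1 `CCc1cc(CCCOc2c(C)cc(-c3noc(C)n3)cc2C)on1` gives 0.183 h, compound 2 `CCc1cc(CCCOc2c(C)cc(-c3noc(C4CC4)n3)cc2C)on1` gives 0.9 h, and compound 3 `Cc1cc(CCCOc2c(C)cc(-c3noc(CC(F)(F)F)n3)cc2C)on1` gives 0.533 h. Compound 2 thus lies within the scatter of compound 3 and clearly apart from compound 1.

Compound 4 `CCOc1cc(CCCOc2c(C)cc(-c3noc(C4CC4)n3)cc2C)on1` differs from compound 2 in one place: ethoxy in place of ethyl on an aromatic carbon. The ethoxy group of compound 4 sits next to the ring nitrogen and two ring bonds from the ring oxygen.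

Among the compounds with values here, only one measured step changes a single place, a 4.9-fold higher number from compound 1 to compound 2 (0.69 log units; beyond the scatter). This modest step, beyond the scatter, puts cyclopropyl in place of methyl at a different place in the molecule, so it bears only indirectly. It shows that a small substituent swap can move this read-out, but it gives no direction for ethoxy. Within the data shown here, no measured pair isolates a change at the ethyl group, so no step beyond the scatter is expected, though the uncertainty is wide. The estimated change is a 1.3-fold lower number from compound 2 to compound 4 (0.11 log units; within the scatter). The half-life expected for compound 4 is 0.7 h, within an estimated range from 0.3 h to 1.6 h.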

Compound 4, half-life: > 2.5 h
Compound 4 ended at the assay's limit; the forecaster's own chance of this, stated with the estimate: 5%; middle value at least 3.5-fold (0.55 log units) from the limit.
By their numbers in this assay, from the lowest: compound 1; then compounds 3 and 2 (each within the scatter of the next). At a limit, above all of these: compound 4.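

Within the data shown here, the step of an at least 2.7-fold higher number from compound 2 to compound 4 (0.44 log units; beyond the scatter) in this assay is the first measured change at this place, on an aromatic carbon next to the ring nitrogen, and it runs toward a longer-lived compound. Among these compounds, the only earlier single-place step lay elsewhere in the molecule, so the earlier compounds could not show that this place also moves the read-out, or in which direction ethoxy would move it. For compound 4, the value of > 2.5 h is a limit of the assay and not a number, so the printed step gives only the least size of the change: the limit of > 2.5 h in this assay, at which 1 of the 4 values shown sits.

With one pair at this place, the compounds shown cannot separate the role of the added oxygen from that of the larger group, and they do not show how far compound 4 truly lies from compound 2. On these data alone, it also remains open whether methoxy, a propoxy chain or an amine at this place would give a similar result, and whether ethoxy would give the same step with methyl in place of cyclopropyl at the other end of the molecule.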